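A Chlorophenyl Cap on a Weakly Active Core

The compounds below may be only part of what the source reports. "The series", "measured", "known", "first", "only" and "open" are said of these compounds alone.

Compound 1, `O=C1COc2ccc(-c3cnc(Cl)c(NS(=O)(=O)c4ccc(F)cc4)c3)cc2N1`: 15600 nM
Compound 2, `O=C1COc2ccc(-c3cnc(Cl)c(NS(=O)(=O)c4ccc(F)cc4)c3)cc2N1c1ccc(Cl)cc1`: a limit of the assay, > 40000 nM
Compound 3, `O=C1COc2ccc(-c3cnc4ccccc4c3)cc2N1`: a limit of the assay, > 40000 nM

Of the compounds shown here, three have been tested in a functional assay on HeLa cells (Homo sapiens) for antiproliferative activity, read by MTT assay, with a stated time of 72 h; on this read-out higher numbers stand for weaker inhibition and lower numbers for stronger inhibition. Among the measured compounds shown here, compound 1 is the only one with a number, giving 15600 nM in this assay. Compound 2 differs from compound 1 by 4-chlorophenyl in place of hydrogen on an amide-type nitrogen in a ring. That change gave an at least 2.5-fold higher number from compound 1 to compound 2 (0.40 log units; beyond the scatter), which is all that can be said when one of the two values is a limit, as the limit of > 40000 nM in this assay, at which 2 of the 3 values shown sit, shows. For compound 3 this assay reports only a limit, > 40000 nM. How the core of compound 3 differs from the core of compound 1 is not broken down here.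

Compound 4, `O=C1COc2ccc(-c3cnc4ccccc4c3)cc2N1c1ccc(Cl)cc1`, is not yet measured. It differs from compound 3 by 4-chlorophenyl in place of hydrogen on an amide-type nitrogen in a ring, and the place is the same word for word as before, so it is the same change. Because the same change earlier gave an at least 2.5-fold higher number from compound 1 to compound 2 (0.40 log units; beyond the scatter), no gain is expected from it here. Compound 4 is therefore expected to show a step that the limit leaves unreadable from compound 3 to compound 4, most likely staying at the limit. The estimate for compound 4 is 70000 nM, expected between 30000 nM and 250000 nM.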

Compound 4, half-maximal inhibitory concentration: > 40000 nM
Compound 4 gave a limit, no number (the forecaster's own chance of this, stated with the estimate: 90%); the middle value does not contradict the limit.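

Compound 3 and compound 4 each give only a limit of the assay in this assay, so no step between them can be read: the limit of > 40000 nM in this assay, at which 3 of the 4 values shown sit.

The compounds shown leave open whether 4-chlorophenyl in place of hydrogen on the amide-type nitrogen changes activity at all on the core of compound 3.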